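Benzylselanyl for methylsulfanyl on two acyl amidine cores

The source may report more compounds than this note shows. Statements on the series, on what has been measured and on what is new or still open speak of the compounds shown alone.

Measured so far:
compound 1 `CS/C(=N\C(=O)c1ccco1)NC(=O)c1ccco1` – > 100000 nM
compound 2 `O=C(/N=C(/NC(=O)c1cccs1)[Se]Cc1ccccc1)c1cccs1` – 58500 nM
compound 3 `CS/C(=N\C(=O)c1cccs1)NC(=O)c1cccs1` – > 100000 nM

All three were tested in a functional assay on K562 cells (Homo sapiens) for cytotoxicity, read by MTT assay, with a stated time of 72 h; a higher number here means a weaker inhibitor of growth, a lower number a stronger inhibitor of growth. Compound 1 gives only a limit of the assay, > 100000 nM. Compound 3 also gives only a limit, > 100000 nM. Compound 2 gives a number, 58500 nM. The change from compound 3 to compound 2 is a group of 8 heavy atoms (7 carbon, 1 selenium; one six-membered aromatic ring of carbon only) in place of a group of 2 heavy atoms (1 carbon, 1 sulfur; no ring), on a carbon with a double bond to nitrogen, and it produced an at least 1.7-fold lower number from compound 3 to compound 2 (0.23 log units; that floor lies within the scatter). The difference between the core of compound 1 and the core of compound 3 is not broken down here. Compound 4 `O=C(/N=C(/NC(=O)c1ccco1)[Se]Cc1ccccc1)c1ccco1` is not yet measured; it differs from compound 1 by a group of 8 heavy atoms (7 carbon, 1 selenium; one six-membered aromatic ring of carbon only) in place of a group of 2 heavy atoms (1 carbon, 1 sulfur; no ring), on a carbon with a double bond to nitrogen, the same change at the same place. Because the earlier change gave an at least 1.7-fold lower number from compound 3 to compound 2 (0.23 log units; that floor lies within the scatter) and because the limit of > 100000 nM in this assay, at which 2 of the 3 values shown sit, holds two of three values, compound 4 is expected to show an at least 1.6-fold lower number from compound 1 to compound 4 (0.22 log units; that floor lies within the scatter). For compound 4 the estimate is 60000 nM, expected between 25000 nM and 150000 nM.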

Compound 4, concentration for total growth inhibition: 44200 nM
Compound 4: the middle estimate sits 1.4-fold (0.13 log units) above what was measured, within the range that was stated.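

In this assay, putting benzylselanyl in place of methylsulfanyl on the core of compound 1 gives an at least 2.2-fold lower number from compound 1 to compound 4 (0.35 log units; beyond the scatter). Both steps of this change start from a limit, so each is only a floor, and a floor says nothing exact about how the two cores compare: the same change on two cores in this assay, an at least 1.7-fold lower number (0.23 log units; that floor lies within the scatter) from compound 3 to compound 2 and an at least 2.2-fold lower number (0.35 log units; beyond the scatter) from compound 1 to compound 4; the limit leaves it open whether they differ The result fits the change carrying over from one core to the other, but it does not show the true size of the step on either core, and that size stays hidden because the starting compounds sit at the ceiling: the limit of > 100000 nM in this assay, at which 2 of the 4 values shown sit.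

The selenium and the benzyl part enter together, so the compounds shown leave open which of them goes with the lower numbers. A benzylsulfanyl or a methylselanyl group on the same carbon would separate the two.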